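Replacing the sulfamoylphenyl amide group with pyridin-2-yl

This account rests on a few compounds, and the source may have more. Where it says the series, first, only, none or still open, it means among the compounds named here.

For the measured compounds named here, compound 2 (`CC(C)n1ncc2c(C(=O)Nc3cccc(S(N)(=O)=O)c3)cc(-c3cccs3)nc21`) gives 25000 nM in an ADME assay on LLC-MK2 cells (Macaca mulatta) for cytotoxicity, read by spectrophotometry and crystal violet staining, with a stated time of 4 days (on this read-out higher numbers stand for lower toxicity in this test and lower numbers for higher toxicity in this test), and that is the only exact number so far. Compound 1 (`CC(C)n1ncc2c(C(=O)Nc3ccc(F)cc3F)cc(-c3cccs3)nc21`) gives > 200000 nM which is a limit of the assay and not a number. Going by the values given here, the one measured step is an at least 8.0-fold lower number from compound 1 to compound 2 (0.90 log units; beyond the scatter) and it came with 3-sulfamoylphenyl in place of 2,4-difluorophenyl on an amide-type nitrogen.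

Compound 3 (`CC(C)n1ncc2c(C(=O)Nc3ccccn3)cc(-c3cccs3)nc21`) changes that same place, with pyridin-2-yl in place of 3-sulfamoylphenyl (pyridin-2-yl in place of 3-sulfamoylphenyl on an amide-type nitrogen). The group that went with the lower number is therefore gone again. Among the compounds with values here, that single step is the only guide, and pyridin-2-yl has not been measured here, so compound 3 is expected to recover only part of it, with a higher number in this assay as the likely direction. The expected change is a 3.2-fold higher number from compound 2 to compound 3 (0.51 log units; beyond the scatter) and it carries wide uncertainty. For compound 3 the estimated value is 80000 nM with an expected range from 30000 nM to 200000 nM in this test series.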

Compound 3, half-maximal cytotoxic concentration: > 200000 nM
Compound 3: a limit, no number; the forecaster's own chance of this, stated with the estimate: 35%; middle value at least 2.5-fold (0.39 log units) from the limit.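

Putting pyridin-2-yl in place of 3-sulfamoylphenyl on the amide-type nitrogen gives an at least 8.0-fold higher number from compound 2 to compound 3 (0.90 log units; beyond the scatter) in this assay. The first pair showed only that one group, 2,4-difluorophenyl, went with a higher number than 3-sulfamoylphenyl, whereas two different groups at this place now do so, and one of them is a ring with a nitrogen in it, so among the three compounds shown the lower number goes with 3-sulfamoylphenyl alone. Compound 1 and compound 3 each stand at a limit of the assay and not at a number, so the step between them cannot be read: the limit of > 200000 nM in this assay, at which 2 of the 3 values shown sit.

Going by these compounds, what remains open is whether the lower number of compound 2 belongs to the sulfamoyl group itself or to the phenyl ring that carries it. A plain phenyl on the amide-type nitrogen, or a phenyl carrying a carboxylic acid or an amine instead of the sulfamoyl group, would be needed to separate these two readings.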